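The compounds below may be only part of what the source reports. "The series", "measured", "known", "first", "only" and "open" are said of these compounds alone.

Measured so far: compound 1 `C#CCOC(=O)/C(C)=C/CC/C(C)=C/CC/C(C)=C/CC[C@@H]1[C@@]2(C)CCC(=O)C(C)(C)[C@H]2CC[C@@]1(C)O` gives 45100 nM in a functional assay on A549 cells (Homo sapiens) for antiproliferative activity, read by MTT assay, with a stated time of 48 h; on this read-out lower numbers stand for stronger inhibition and higher numbers for weaker inhibition; compound 2 `C/C(=C\CC/C(C)=C/CC[C@@H]1[C@@]2(C)CCC(=O)C(C)(C)[C@H]2CC[C@@]1(C)O)CC/C=C(\C)C(=O)OCc1cn(-c2ccccc2)nn1` gives only > 150000 nM there.

On the numbers shown, compound 2 stands at the weak end: its result is a limit of this assay, not a number (the limit of > 150000 nM in this assay, at which 1 of the 2 values shown sits). Compound 3 `C/C(=C\CC/C(C)=C/CC[C@@H]1[C@@]2(C)CCC(=O)C(C)(C)[C@H]2CC[C@@]1(C)O)CC/C=C(\C)C(=O)O` differs from compound 2 in one place: hydrogen in place of (1-phenyl-1H-1,2,3-triazol-4-yl)methyl on an oxygen next to a carbonyl group. Among the compounds with values here, the only measured step, an at least 3.3-fold higher number from compound 1 to compound 2 (0.52 log units; beyond the scatter), changed the group on that same oxygen, but to a different group, so it bears on this change only loosely. A step back toward a measurable number is expected, namely an at least 2.5-fold lower number from compound 2 to compound 3 (0.39 log units; beyond the scatter). Compound 3 is expected to give about 60000 nM, within 20000 nM to 200000 nM.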

Compound 3, half-maximal inhibitory concentration: > 150000 nM
Compound 3 ended at the assay's limit; the forecaster's own chance of this, stated with the estimate: 35%; middle value at least 2.5-fold (0.39 log units) from the limit.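

In this assay compound 3 gives > 150000 nM, which is a limit of the assay and not a number. Hydrogen in place of propargyl on this oxygen gives an at least 3.3-fold higher number from compound 1 to compound 3 (0.52 log units; beyond the scatter), so neither replacement shown keeps a measurable number. The step between compound 2 and compound 3 cannot be read, as two of the values are now limits: the limit of > 150000 nM in this assay, at which 2 of the 3 values shown sit.

Still open, going by these compounds, is whether the propargyl group itself is needed, or whether a methyl ester or an amide at this carbonyl would also give a number. On these data alone, how far compound 2 and compound 3 lie beyond the limit also remains unknown.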